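Nitro for Hydrogen on Two Amide Cores: Cytotoxicity Notes

The compounds below may be only part of what the source reports. "The series", "measured", "known", "first", "only" and "open" are said of these compounds alone.

Compound 1 `Cc1cc(NC(=O)c2ccc(Cl)cc2)ccc1NS(=O)(=O)C(F)(F)F` is measured in an ADME assay on RAW264.7 cells (Mus musculus) for cytotoxicity, read by MTT assay, with a stated time of 48 h (a lower number here means a stronger inhibitor, a higher number a weaker inhibitor), where compound 1 gives 35400 nM. Compound 2 `Cc1cc(NC(=O)c2ccc(Cl)c([N+](=O)[O-])c2)ccc1NS(=O)(=O)C(F)(F)F` carries the change (nitro in place of hydrogen on an aromatic carbon); in this assay compound 2 gives 89800 nM, and the step of a 2.5-fold higher number from compound 1 to compound 2 (0.40 log units; beyond the scatter). Compound 3 `CS(=O)(=O)Nc1ccc(NC(=O)c2ccc(Cl)cc2)cc1Cl` rests on a different core; the difference between the two cores is not broken down here. In this assay compound 3 gives 79900 nM, within the scatter of compound 2 and beyond it from compound 1. Compound 4 `CS(=O)(=O)Nc1ccc(NC(=O)c2ccc(Cl)c([N+](=O)[O-])c2)cc1Cl` is not yet measured; it differs from compound 3 by nitro in place of hydrogen on an aromatic carbon, the same change as from compound 1 to compound 2, the surroundings of the place matching word for word. Compound 4 is expected to give 180000 nM, estimated between 80000 nM and 400000 nM. Among the measured compounds shown here, this rests on the one earlier instance of the change, which showed a 2.5-fold higher number from compound 1 to compound 2 (0.40 log units; beyond the scatter). The expected step is a 2.3-fold higher number from compound 3 to compound 4 (0.35 log units; beyond the scatter). One precedent on another core carries limited weight.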

Compound 4, half-maximal inhibitory concentration: 43600 nM
For compound 4 the middle estimate is 4.1-fold (0.62 log units) above the measured one; measured number outside the range, below it.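

In this assay, nitro in place of hydrogen on an aromatic carbon gives a 1.8-fold lower number from compound 3 to compound 4 (0.26 log units; within the scatter), so on the core of compound 3 the step does not stand clear of the scatter. The step of the core of compound 1, a 2.5-fold higher number from compound 1 to compound 2 (0.40 log units; beyond the scatter), therefore does not carry over to the other core, although the surroundings of the place match: the same change on two cores in this assay, a 2.5-fold higher number (0.40 log units; beyond the scatter) from compound 1 to compound 2 and a 1.8-fold lower number (0.26 log units; within the scatter) from compound 3 to compound 4, 4.6-fold (0.67 log units) apart, beyond the scatter of two such steps

With one pair on each core, this shows that the step cannot be assumed to transfer within this series, but not which difference between the cores goes with the gap.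

Still open, as far as these compounds go, is how an amine or a nitrile in place of the nitro would behave on these two cores. A core joining the trifluoromethyl group of compound 1 to the chloro group of compound 3 could separate the two core differences.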